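Benzylamino amide from a methyl ester on a shared core

The source may hold more compounds than are shown below. What is called first, only, known or untested is meant among the compounds shown, and "the series" means these compounds.

Compound 1 `N[C@H]1CC[C@H](Nc2c(C(=O)NCc3ccc(Cl)cc3)nc(Br)c3cccnc23)CC1`: 2000 nM
Compound 2 `COC(=O)c1nc(Br)c2cccnc2c1N[C@H]1CC[C@H](N)CC1`: "not determined" (no result reported)

In a functional assay on SK-BR-3 cells (Homo sapiens) for cytotoxicity, read by MTT assay, with a stated time of 72 h (a higher number here means a weaker inhibitor, a lower number a stronger inhibitor), compound 1 gives 2000 nM. Compound 2 has no number of its own in this assay, so compound 2 stands nowhere on the measured scale. Compound 3 `N[C@H]1CC[C@H](Nc2c(C(=O)NCc3ccccc3)nc(Br)c3cccnc23)CC1` is the not yet measured partner of compound 2. The change from compound 2 to compound 3 is benzylamino in place of methoxy on a carbonyl carbon. Among the compounds with values here, no step between measured compounds is available to size this change, so its direction and magnitude in this assay cannot be read from the data. Within the data shown here, what remains is compound 1, whose value of 2000 nM is the only number at hand and whose structure shares the core and the carboxamide pattern of compound 3. Compound 3 is therefore expected to land near compound 1, and its estimated value in this assay is 2500 nM, with a range from 800 nM to 8000 nM.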

Compound 3, half-maximal inhibitory concentration: 8000 nM
Compound 3: the middle estimate sits 3.2-fold (0.51 log units) below what was measured, and the stated range covers the measured number.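

Within the data shown here, with hydrogen in place of chloro on an aromatic carbon, this assay shows a 4.0-fold higher number from compound 1 to compound 3 (0.60 log units; beyond the scatter), the first step that can be sized. The aromatic ring that enters with benzylamino is therefore not indifferent to what it carries: in this one pair, the chloro compound 1 is the stronger inhibitor, by a modest margin beyond the scatter, while the step from methoxy to benzylamino still cannot be read. No measurement at hand accounts for the difference.

The compounds shown leave open whether fluoro, methyl or methoxy on that aromatic carbon would match chloro or fall nearer hydrogen. They also leave open how a longer chain between the amide nitrogen and the ring, or a carboxylic acid on the carbonyl carbon, would read in this assay.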